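This account rests on a few compounds, and the source may have more. Where it says the series, first, only, none or still open, it means among the compounds named here.

Measured so far:
- compound 1 `Cc1nc(S(C)(=O)=O)ccc1Oc1ncnc(OC2CCN(C(=O)OC(C)C)CC2)c1F` — 21 nM
- compound 2 `Cc1nc(S(C)(=O)=O)ccc1Oc1ncnc(OC2CCN(C(=O)O[C@H](C)CF)CC2)c1F` — 196 nM

Compound 2 holds the highest of the two numbers in a functional assay on isolated protein for inhibition of Glucose-dependent insulinotropic receptor (Homo sapiens), read by HTRF and cAMP accumulation; on this read-out higher numbers stand for an effect only at larger amounts of compound and lower numbers for an effect already at smaller amounts; compound 1 sits closer to the potent end. Among the measured compounds shown here, the only measured step, a 9.3-fold higher number from compound 1 to compound 2 (0.97 log units; beyond the scatter), is the one that bears on the next change: compound 3 `Cc1nc(S(C)(=O)=O)ccc1Oc1ncnc(OC2CCN(C(=O)O[C@H](C)C(F)(F)F)CC2)c1F` carries trifluoromethyl in place of fluoromethyl on a saturated chain carbon bound to an oxygen next to a carbonyl group and a saturated chain carbon, a further fluorination at the same carbamate carbon. Compound 3 is therefore expected to move in the same direction as that step, though more weakly, because the step of a 9.3-fold higher number from compound 1 to compound 2 (0.97 log units; beyond the scatter) already consumed part of the loss. The estimate for compound 3 in this assay is 400 nM, range 130 nM to 1200 nM, meaning an expected step of a 2.0-fold higher number from compound 2 to compound 3 (0.31 log units; beyond the scatter).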

Compound 3, half-maximal effective concentration: 9.2 nM
Compound 3: middle estimate off by 43-fold (1.64 log units), on the high side; measured number below the stated range.
By their numbers in this assay, from the lowest: compound 3; then compound 1; then compound 2.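

In this assay, fluorination on this saturated chain carbon does not push the number in one direction: trifluoromethyl in place of fluoromethyl gives a 21-fold lower number from compound 2 to compound 3 (1.33 log units; beyond the scatter), reversing the loss seen with fluoromethyl. Against the unfluorinated carbamate, 1-(trifluoromethyl)ethyl in place of isopropyl gives a 2.3-fold lower number from compound 1 to compound 3 (0.36 log units; beyond the scatter), so compound 3 has the lowest number of the three. Nothing at hand accounts for this reversal.

From the compounds shown here alone, whether difluoromethyl at this carbon would track fluoromethyl or trifluoromethyl remains open. Going by these compounds, the effects of the opposite stereochemistry at this carbon and of a longer chain such as pentafluoroethyl also remain open.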